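The source may report more compounds than this note shows. Statements on the series, on what has been measured and on what is new or still open speak of the compounds shown alone.

Compound 3 `CC(C)(C)c1cc(N)c2cc(NC(=O)/C=C/c3ccc(C(F)(F)F)cc3)ccc2n1` gives 29 nM in a functional assay on HEK293 cells for activation of melanin-concentrating hormone receptor 1 (Homo sapiens), read by inositol phosphate accumulation (on this read-out higher numbers stand for an effect only at larger amounts of compound and lower numbers for an effect already at smaller amounts), the lowest of the three numbers in hand. Its nearest neighbour is compound 2 `CC(C)c1cc(N)c2cc(NC(=O)/C=C/c3ccc(C(F)(F)F)cc3)ccc2n1`, which gives 160 nM; the furthest is compound 1 `CCCc1cc(N)c2cc(NC(=O)/C=C/c3ccc(Cl)cc3Cl)ccc2n1`, which carries a different substituent on the cinnamoyl ring as well and gives 904 nM.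

The next compound, compound 4 `Cc1cc(N)c2cc(NC(=O)/C=C/c3ccc(C(F)(F)F)cc3)ccc2n1`, differs from compound 3 in one place: methyl in place of tert-butyl on an aromatic carbon. Going by the values given here, the change runs the opposite way from the only measured step that bears on it, a 5.5-fold lower number from compound 2 to compound 3 (0.74 log units; beyond the scatter). There, adding a single methyl on the saturated chain carbon brought a clearly lower number; here three such carbons are taken away at once, so the shared core of compound 4 carries only a methyl where compound 3 carries a tert-butyl.

On that basis the step is expected to go upward, toward a higher number, and to be larger than the measured step because it reverses a 5.5-fold lower number from compound 2 to compound 3 (0.74 log units; beyond the scatter) and goes further in the same direction. Compound 4 is estimated to give 400 nM in this assay, with a plausible range from 100 nM to 1500 nM, which corresponds to an expected step of a 14-fold higher number from compound 3 to compound 4 (1.14 log units; beyond the scatter).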

Compound 4, half-maximal effective concentration: 140 nM
Compound 4: the middle estimate sits 2.9-fold (0.46 log units) above what was measured, within the range that was stated.
By their numbers in this assay, from the lowest: compound 3; then compounds 4 and 2 (each within the scatter of the next); then compound 1.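

In this assay, the group next to the ring nitrogen can now be compared across three compounds on the shared core, and tert-butyl stands apart: replacing it with methyl gives a 4.8-fold higher number from compound 3 to compound 4 (0.68 log units; beyond the scatter). Methyl and isopropyl, by contrast, cannot be told apart, with a 1.1-fold lower number from compound 2 to compound 4 (0.06 log units; within the scatter), so the earlier step of a 5.5-fold lower number from compound 2 to compound 3 (0.74 log units; beyond the scatter) does not mark the start of a gradual trend with each added carbon, and among these three groups only tert-butyl brings the lower number. Nothing available here explains why the response to this change is so uneven.

The compounds shown leave open whether the lower number is specific to tert-butyl or would also appear with other groups at this position, such as a cyclopropyl ring, a phenyl ring or a longer chain. Compound 1 carries a propyl chain but also differs from the others in a second place, so the effect of that chain alone, and whether the preference for tert-butyl holds with other substituents elsewhere on the shared core, remain unresolved.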